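The source may hold more compounds than are shown below. What is called first, only, known or untested is meant among the compounds shown, and "the series" means these compounds.

Measured so far:
compound 1, `CCN(Cc1cccs1)C(=O)COc1ccccc1`, in an assay on HEK293 cells for agonist activity at transient receptor potential cation channel subfamily M member 8 (Homo sapiens), read by fluorescence and calcium flux, with a stated time of 15 min (on this read-out lower numbers stand for an effect already at smaller amounts and higher numbers for an effect only at larger amounts of compound), compound 1 gives 1400 nM.
compound 2, `CCN(Cc1cccs1)C(=O)C[C@@H](O)c1ccccc1`, compound 2 is reported as "not active" (no number reported), without a number.
compound 3, `Cc1ccc(OCC(=O)N(Cc2cccs2)c2ccnn2C)cc1`, compound 3 gives 422 nM.

Compound 3 holds the lowest of the two numbers measured; the nearest is compound 1, whose number is higher by a margin beyond the usual scatter, and compound 2 stands apart as an entry without a single number.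

The next compound, compound 4, `Cc1ccc(OCC(=O)N(O)Cc2cccs2)cc1`, is set beside compound 3. The change is hydroxy in place of 1-methyl-1H-pyrazol-5-yl on an amide-type nitrogen. Within the data shown here, no directly comparable step between measured compounds exists, so the expectation rests on the two numbers and the structural change alone. Among the measured compounds shown here, the only compound with a different group on that nitrogen, compound 1, gives the higher number, and compound 2 gives no number at all. The expectation is therefore a step toward higher numbers, of a size beyond the scatter, when compound 4 is measured: the step from compound 3 to compound 4 is expected to be a 4.7-fold higher number from compound 3 to compound 4 (0.68 log units; beyond the scatter). Compound 4 is estimated at 2000 nM, with a range from 600 nM to 8000 nM.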

Compound 4, half-maximal effective concentration: 8000 nM
Compound 4: middle estimate off by 4.0-fold (0.60 log units), on the low side, and the stated range covers the measured number.
By their numbers in this assay, from the lowest: compound 3; then compound 1; then compound 4.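

In this assay, among these compounds, hydroxy in place of 1-methyl-1H-pyrazol-5-yl on the amide-type nitrogen gives a 19-fold higher number from compound 3 to compound 4 (1.28 log units; beyond the scatter) as a large step, and it is the only step so far between compounds that differ in one place. The group on this nitrogen therefore shifts the read-out well beyond the scatter, with the rest of the structure unchanged, which compounds 1 and 2 could not show as they differ from compound 3 in more than one place. The exchange replaces a five-membered aromatic ring of 6 heavy atoms and 0 hydrogen-bond donors with a single oxygen carrying 1 hydrogen-bond donor, and no measurement at hand separates these differences or accounts for the size of the step.

Still open, from the compounds shown here alone, is how the read-out responds to other groups on the same nitrogen, such as methoxy, cyclopropyl or a dimethylamino-bearing chain, which would help show whether the ring itself or simply a larger carbon-containing group matters. Also open, going by these compounds, is whether other five-membered aromatic rings with 2 hetero atoms would keep the lower number of compound 3.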